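A few compounds are considered here, and "the series" means these few. Any claim that something is new, unique, unknown or untested is made for them only; others in the source may bear on it.

Measured compounds:
- compound 1, `O=c1c2ccccc2[se]n1-c1nnc(-c2ccc(Br)cc2)s1`, 43300 nM in a functional assay on MCF7 cells (Homo sapiens) for antiproliferative activity, read by CCK-8 assay, with a stated time of 48 h; a higher number here means a weaker inhibitor, a lower number a stronger inhibitor
- compound 2, `COc1ccc(-c2nnc(-n3[se]c4ccccc4c3=O)s2)cc1`, 10000 nM in this assay
- compound 3, `O=c1c2ccccc2[se]n1-c1nnc(-c2ccccc2Cl)s1`, 4430 nM in this assay

Among these three, compound 3 gives the lowest number in this assay, that is, it is the strongest inhibitor of the three. Its nearest neighbour is compound 2, and the step to compound 1 is the largest gap in the set.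

Compound 4, `O=c1c2ccccc2[se]n1-c1nnc(-c2ccccc2Br)s1`, has not yet been measured in this assay. It differs from compound 3 in one place: bromo in place of chloro on an aromatic carbon. The bromo sits on an aromatic carbon of a six-membered aromatic ring of carbon only, ortho to a large group.

Within the data shown here, no measured step swaps chloro for bromo at the same place. The two known steps change other things: a 4.3-fold lower number from compound 1 to compound 2 (0.64 log units; beyond the scatter), and a 9.8-fold lower number from compound 1 to compound 3 (0.99 log units; beyond the scatter). Both concern the group on that ring, but neither isolates a halogen-for-halogen swap, so they give only loose guidance.

An exchange of one halogen for a closely related one is expected to move the number little, so for compound 4 a step of a 1.1-fold lower number from compound 3 to compound 4 (0.04 log units; within the scatter) is expected, within the scatter. Compound 4 is therefore estimated at 4000 nM, with a range from 1500 nM to 12000 nM.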

Compound 4, half-maximal inhibitory concentration: 59400 nM
Compound 4: middle estimate off by 15-fold (1.17 log units), on the low side, outside the stated range (above it).
By their numbers in this assay, from the lowest: compound 3; then compound 2; then compounds 1 and 4 (each within the scatter of the next).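

In this assay the step of a 13-fold higher number from compound 3 to compound 4 (1.13 log units; beyond the scatter) shows that on this aromatic carbon, ortho to a large group, chloro and bromo are not interchangeable, even though each is a single halogen atom with no hydrogen-bond donors or acceptors. The step of a 1.4-fold higher number from compound 1 to compound 4 (0.14 log units; within the scatter) shows that, with bromo on the phenyl ring, 2-bromophenyl and 4-bromophenyl cannot be told apart in this assay, so the low number of compound 3 depends on chloro rather than on this place alone. Nothing available here explains why the halogen swap has so large an effect.

Going by these compounds, whether a fluoro, a methyl or an amine at this place would behave like chloro or like bromo remains open. The favourable chloro result also rests on compound 3 alone.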